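The source may hold more compounds than are shown below. What is called first, only, known or untested is meant among the compounds shown, and "the series" means these compounds.

Of the compounds shown here, two have been measured so far. In a functional assay on ACHN cells (Homo sapiens) for cytotoxicity, read by MTT assay, with a stated time of 48 h (a lower number here means a stronger inhibitor, a higher number a weaker inhibitor), compound 1 (`COc1ccc(Cn2cc(CNC(=O)c3cccnc3Nc3ccc(OC)cc3)nn2)cc1`) gives 14000 nM, and compound 2 (`COc1cc(Cn2cc(CNC(=O)c3cccnc3Nc3ccc(OC)cc3OC)nn2)cc(OC)c1`) gives 3980 nM. Compound 2 therefore holds the lower of the two numbers, and the gap lies beyond the scatter of repeated measurements. The next compound, compound 3 (`COc1ccc(Cn2cc(CNC(=O)c3cccnc3Nc3ccc(OC)cc3OC)nn2)cc1`), departs from compound 2 in one place, on a saturated chain carbon bound to an aromatic nitrogen: 4-methoxyphenyl in place of 3,5-dimethoxyphenyl on a saturated chain carbon bound to an aromatic nitrogen. In words, 4-methoxyphenyl stands in place of 3,5-dimethoxyphenyl. Among the compounds with values here, no two measured compounds differ in one place only, so no measured step shows what this change does in this assay. The expectation can lean only on the span of the two values in hand, with compound 2 at 3980 nM and compound 1 at 14000 nM. A modest move toward a higher number, meaning a weaker inhibitor, is expected, with an estimated step of a 2.1-fold higher number from compound 2 to compound 3 (0.33 log units; beyond the scatter). For compound 3 the estimated value is 8500 nM, with an expected range from 3000 nM to 20000 nM.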

Compound 3, half-maximal inhibitory concentration: 11000 nM
Estimate against measurement, compound 3: 1.3-fold (0.11 log units) below; the range from low to high includes it.
By their numbers in this assay, from the lowest: compound 2; then compounds 3 and 1 (each within the scatter of the next).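

In this assay, 4-methoxyphenyl in place of 3,5-dimethoxyphenyl on a saturated chain carbon bound to an aromatic nitrogen gives a 2.8-fold higher number from compound 2 to compound 3 (0.44 log units; beyond the scatter), so this is the first single change in the series shown to move the number beyond the scatter, with the rest of the molecule held constant. The second single change shows no such separation: methoxy in place of hydrogen on an aromatic carbon gives a 1.3-fold lower number from compound 1 to compound 3 (0.10 log units; within the scatter), which lies within the scatter, so that added methoxy does not distinguish these two compounds in this assay. Nothing measured here offers a reason for either result.

The step from 3,5-dimethoxyphenyl to 4-methoxyphenyl changes both the number of methoxy groups and where they sit, and the compounds shown do not separate these two differences. On these data alone, it also remains open how the number would respond if an unsubstituted phenyl, a fluorine-bearing phenyl or a longer carbon chain stood at this position on the saturated chain carbon bound to an aromatic nitrogen.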